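A few compounds are considered here, and "the series" means these few. Any claim that something is new, unique, unknown or untested is made for them only; others in the source may bear on it.

In a functional assay on MCF7 cells (Homo sapiens) for inhibition (a higher number here means a weaker inhibitor, a lower number a stronger inhibitor), three compounds have been measured, and each gives only a limit rather than a number. Compound 1 `Nc1cc(Br)c(-c2nc3ccccc3o2)c(Br)c1` gives < 10 nM, which is a limit. Compound 2 `Cc1ccc2nc(-c3ccc(N)cc3I)sc2c1` gives < 0.1 nM, also a limit. Compound 3 `Nc1ccc(-c2nc3ccccc3s2)cc1Cl` gives < 0.1 nM, likewise a limit, so it stands at the same limit as compound 2 and has no exact value. None of the three can therefore be ranked against the others.

Compound 4 `COc1cccc2sc(-c3ccc(N)c(Cl)c3)nc12` differs from compound 3 by methoxy in place of hydrogen on an aromatic carbon, with methoxy in place of hydrogen on an aromatic carbon, ortho to a fused ring. No measured pair among these compounds shows what such a change does, so any forecast is uncertain. A weaker inhibitor is expected, with an estimated step of an at least 10-fold higher number from compound 3 to compound 4 (1.00 log units; beyond the scatter) that goes beyond the usual scatter. In this assay, the estimate for compound 4 is 1 nM, with an expected range from 0.05 nM to 50 nM.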

Compound 4, half-maximal inhibitory concentration: > 10000 nM
Compound 4 was reported as a limit (the forecaster's own chance of this, stated with the estimate: 35%); at least 10000-fold (4.00 log units) between middle value and limit.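

In this assay, methoxy in place of hydrogen on an aromatic carbon, ortho to a fused ring, gives the first step that can be read among these compounds: an at least 100000-fold higher number from compound 3 to compound 4 (5.00 log units; beyond the scatter). Both ends of this step are limits, so the true gap could be wider still, yet it shows that this one change at this position can abolish nearly all the inhibition seen with compound 3. Until now every value sat at the strong end, and compound 4 is the only one at the weak end: the limit of > 10000 nM in this assay, at which 1 of the 4 values shown sits.

As far as these compounds go, whether hydroxyl, fluorine or ethoxy at the same position would keep the strength of compound 3 stays open, as does the effect of methoxy elsewhere on that ring. These compounds alone do not tell why the loss occurs.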